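The source may report more compounds than this note shows. Statements on the series, on what has been measured and on what is new or still open speak of the compounds shown alone.

Measured so far:
compound 1, `CCCCCCCCCCCCCCCCCCNC(=O)[C@H]1CSC(c2c[nH]c3ccccc23)N1`
compound 2, `CCCCCCCCCCCCCCCCCCNC(=O)[C@H]1CSC(c2ccc([N+](=O)[O-])cc2)N1`

In a functional assay on LNCaP cells (Prostate gland, Homo sapiens) for antiproliferative activity, read by sulforhodamine B assay (a higher number here means a weaker inhibitor, a lower number a stronger inhibitor), compound 1 gives 2100 nM and compound 2 gives 8400 nM. Among the measured compounds shown here, compound 2 stands at the higher of the two numbers; its only neighbour is compound 1, reached through a 4.0-fold higher number from compound 1 to compound 2 (0.60 log units; beyond the scatter), which is the single measured step in the set.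

Compound 3, `CCCCCCCCCCCCCCCCCCNC(=O)[C@H]1CSC(c2ccc(C)cc2)N1`, has not yet been measured in this assay. It differs from compound 2 by methyl in place of nitro on an aromatic carbon. For the measured compounds named here, no measured pair changes only this substituent, so nothing in the numbers speaks directly to it. Going by the values given here, the one measured step exchanges the whole aromatic group on the saturated ring carbon, and that step was modest; a substituent exchange on a phenyl that is itself retained is a smaller edit, so a step no larger than that one is expected, and its direction cannot be read from the data. For compound 3 the expected value in this assay is 6000 nM, with a range from 2000 nM to 18000 nM. The expected step from compound 2 is therefore a 1.4-fold lower number from compound 2 to compound 3 (0.15 log units; within the scatter), which may well fall within the scatter.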

Compound 3, half-maximal inhibitory concentration: 1900 nM
The estimate for compound 3 lay 3.2-fold (0.50 log units) above the measured number; measured number outside the range, below it.
By their numbers in this assay, from the lowest: compounds 3 and 1 (each within the scatter of the next); then compound 2.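

In this assay, methyl in place of nitro on the retained phenyl ring, para to a large group, gives a 4.4-fold lower number from compound 2 to compound 3 (0.65 log units; beyond the scatter), so a single substituent at this position matters as much as the exchange of the whole aromatic group did in a 4.0-fold higher number from compound 1 to compound 2 (0.60 log units; beyond the scatter). The new step also shows that 4-methylphenyl and 1H-indol-3-yl on the saturated ring carbon cannot be told apart in this assay, with a 1.1-fold lower number from compound 1 to compound 3 (0.04 log units; within the scatter). Among the three compounds, compound 2 alone stands apart, which ties its higher number to the nitro group rather than to a phenyl ring in place of the indole. No supporting measurement accompanies this result, so the numbers give no explanation for the nitro to methyl difference.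

Two substituents cannot show whether the nitro group is the exception or the methyl group is, and an unsubstituted phenyl, a 4-chlorophenyl or a 4-methoxyphenyl would begin to separate those readings. On these data alone, how far these aromatic differences persist with a shorter chain on the amide, or with a free carboxylic acid in place of the amide, also stays open.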